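Working notes on compound 4 and its expected cytotoxicity

This account rests on a few compounds, and the source may have more. Where it says the series, first, only, none or still open, it means among the compounds named here.

Measured so far:
- compound 1 `Cc1cn([C@@H]2O[C@H](CO[Si](C)(C)C(C)(C)C)[C@@]3(OS(=O)(=O)C=C3NCC(=O)C(=O)N3CCC3)[C@H]2O[Si](C)(C)C(C)(C)C)c(=O)n(C)c1=O` — 65000 nM
- compound 2 `CCOC(=O)NC(=O)NC1=CS(=O)(=O)O[C@@]12[C@@H](CO[Si](C)(C)C(C)(C)C)O[C@@H](n1cc(C)c(=O)n(C)c1=O)[C@@H]2O[Si](C)(C)C(C)(C)C` — 16000 nM
- compound 3 `Cc1cn([C@@H]2O[C@H](CO[Si](C)(C)C(C)(C)C)[C@@]3(OS(=O)(=O)C=C3NC(=O)c3ccccc3)[C@H]2O[Si](C)(C)C(C)(C)C)c(=O)n(C)c1=O` — limit only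

In a functional assay on HEL cells (Homo sapiens) for cytotoxicity, read by microscopy (on this read-out higher numbers stand for lower toxicity in this test and lower numbers for higher toxicity in this test), compound 1 gives 65000 nM and compound 2 gives 16000 nM. For compound 3 this assay reports only a limit, >= 3200 nM. Compound 2 holds the lowest of the two readable numbers; its nearest neighbour is compound 1, with a 4.1-fold lower number from compound 1 to compound 2 (0.61 log units; beyond the scatter). The steps to compound 3 stay unreadable: a step that the limit leaves unreadable from compound 1 to compound 3 and a step that the limit leaves unreadable from compound 2 to compound 3, both hidden by the limit of >= 3200 nM in this assay, at which 1 of the 3 values shown sits.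

Compound 4 `Cc1cn([C@@H]2O[C@H](CO[Si](C)(C)C(C)(C)C)[C@@]3(OS(=O)(=O)C=C3NCC(=O)C(N)=O)[C@H]2O[Si](C)(C)C(C)(C)C)c(=O)n(C)c1=O` is the next member. It differs from compound 2 as follows: (carbamoylcarbonyl)methyl in place of (ethoxycarbonyl)carbamoyl on an amine nitrogen. Among the compounds with values here, the only readable step, a 4.1-fold lower number from compound 1 to compound 2 (0.61 log units; beyond the scatter), concerns a change at the same amine nitrogen and is modest. Compound 4 carries a (carbamoylcarbonyl)methyl group, closer in kind to the (((azetidin-1-yl)carbonyl)carbonyl)methyl group of compound 1 than to the (ethoxycarbonyl)carbamoyl group of compound 2, so a return toward the number of compound 1 is expected rather than a move beyond it.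

For compound 4 the expected step is a 2.5-fold higher number from compound 2 to compound 4 (0.40 log units; beyond the scatter), a modest rise in this assay. Compound 4 is therefore estimated at 40000 nM, within 15000 nM to 100000 nM.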

Compound 4, minimum cytotoxic concentration: >= 16000 nM
Compound 4 was reported as a limit; the forecaster's own chance of this, stated with the estimate: 20%; the middle value is on the limit's open side.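

Compound 4 is reported in this assay only as a limit, >= 16000 nM. From the compounds shown here alone, exchanging (ethoxycarbonyl)carbamoyl for (carbamoylcarbonyl)methyl on the amine nitrogen gives a number no lower from compound 2 to compound 4 (the limit leaves the size open), so the shorter group, which ends in amino rather than azetidin-1-yl on its carbonyl carbon, does not bring the number under that of compound 2, although the size of the rise remains unknown. The steps from compound 1 and from compound 3 to compound 4 cannot be read: the limit of >= 16000 nM in this assay, at which 1 of the 4 values shown sits.

Going by these compounds, it therefore remains open whether amino and azetidin-1-yl on that carbonyl carbon differ at all in this test, and how far compound 3 and compound 4 stand from the other compounds. Also open, on these data alone, is how the number would respond to a carboxylic acid or a dimethylamino group on that carbonyl carbon, or to a longer chain in place of (carbamoylcarbonyl)methyl on the amine nitrogen.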